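The source may report more compounds than this note shows. Statements on the series, on what has been measured and on what is new or still open speak of the compounds shown alone.

Compound 1, `COc1cc(/C=C/C=C/C(=O)N2CCCCC2)cc(OC)c1OC`, in an assay for inhibition of Polyunsaturated fatty acid 5-lipoxygenase (Homo sapiens), read by spectrophotometry, tested at 20 uM (a higher number here means more inhibition at the concentration tested (going by the name of the read-out), a lower number less inhibition), gives 66.7%.
Compound 2, `O=C(/C=C/C=C/c1ccc(Cl)cc1)N1CCCCC1`, in this assay gives 14.5%.
Compound 3, `O=C(/C=C/C=C/c1cc(O)c(O)c(O)c1)N1CCCCC1`, in this assay gives 82.5%.

Compound 2 stands lowest of the three numbers; compound 1 sits nearest, beyond the scatter above it, and compound 3 lies furthest, also beyond the scatter above it. Compound 4, `O=C(/C=C/C=C/c1ccc(F)cc1)N1CCCCC1`, is not yet measured. It differs from compound 2 as follows: fluoro in place of chloro on an aromatic carbon. Among the measured compounds shown here, no measured pair shows this change, so in this assay the step from compound 2 to compound 4 is expected to be none beyond the scatter, in either direction. Accordingly compound 4 is estimated at 13%, with a range of 0% to 30%, which means an expected step of a number 1.5 percentage points lower from compound 2 to compound 4 (within the scatter).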

Compound 4, a percentage reported as inhibition, at one concentration (the size of the read-out at that concentration, not a potency): 48.7%
Compound 4: the middle estimate sits 35.7 percentage points below what was measured; the measured number lies above the stated range.
By their numbers in this assay, from the lowest: compound 2; then compound 4; then compound 1; then compound 3.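

In this assay, fluoro in place of chloro on the aromatic carbon para to a large group gives a number 34.2 percentage points higher from compound 2 to compound 4 (beyond the scatter). Among the compounds shown here, this is the first pair that differs in one place, and it shows that this position responds strongly to which group sits there, even though the heavy-atom, donor and acceptor counts stay the same. Nothing available explains the size of this step.

Open, on these data alone, is where bromo or an amine at this position would fall relative to compound 2 and compound 4. A single pair also leaves open whether the step carries over to other substitution patterns on the ring.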